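Stereochemistry and inhibition of a cytosolic glycosidase

The source may hold more compounds than are shown below. What is called first, only, known or untested is meant among the compounds shown, and "the series" means these compounds.

Measured compounds:
compound 1 `O=C(O)[C@H]1NCC=C[C@H]1O`, 17%
compound 2 `O=C(O)[C@H]1NC[C@H](O)[C@@H](O)[C@H]1O`, 2.6%
compound 3 `O=C(O)[C@H]1NC[C@@H](O)[C@H](O)[C@@H]1O`, 42%

In an assay on isolated protein for inhibition of cytosolic endo-beta-N-acetylglucosaminidase (Homo sapiens), tested at 1000 uM (a lower number here means less inhibition, a higher number more inhibition at the concentration tested (going by the name of the read-out)), compound 3 stands highest of the three, with compound 1 nearest and compound 2 furthest behind. Among the compounds with values here, the only measured step that changes configuration alone, a number 39.4 percentage points higher from compound 2 to compound 3 (beyond the scatter), was large, and it rested on (the fact that compounds 2 and 3 differ only in the configuration as drawn). Compound 4 `O=C(O)[C@@H]1NC[C@@H](O)[C@H](O)[C@H]1O` is the next member; it differs from compound 3 as follows: the two compounds have the same atoms and bonds and differ only in configuration as drawn: 2 of 4 stereo elements differ; a stereocentre at a saturated ring carbon is drawn S in compound 3 and R in compound 4; a stereocentre at a saturated ring carbon is drawn R in compound 3 and S in compound 4. Since rearranging stereocentres on this core moved this assay by a large amount in the one measured case, a step beyond the scatter is expected here too, most likely downward, as compound 3 already sits at the top. Compound 4 is therefore expected to give 15%, between 0% and 45%, a step of a number 27 percentage points lower from compound 3 to compound 4 (beyond the scatter).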

Compound 4, a percentage reported as inhibition, at one concentration (the size of the read-out at that concentration, not a potency): 50%
Compound 4: middle estimate off by 35 percentage points, on the low side; the measured number lies above the stated range.
By their numbers in this assay, from the lowest: compound 2; then compound 1; then compounds 3 and 4 (each within the scatter of the next).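

Changing configuration does not always move the number on this shared core: in this assay, two of the four stereo elements differ in the step of a number 8 percentage points higher from compound 3 to compound 4 (within the scatter). With three of the four differing, the step of a number 47.4 percentage points higher from compound 2 to compound 4 (beyond the scatter) is large, and it again involves configuration alone: the fact that compounds 2 and 4 differ only in the configuration as drawn

The compounds shown leave open which single stereocentre carries the large steps, as every step here changes two or more at once. They also leave open how an amide in place of the carboxylic acid would read in this assay.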